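Chloro step carried across two cores: cytotoxicity notes

The source may report more compounds than this note shows. Statements on the series, on what has been measured and on what is new or still open speak of the compounds shown alone.

Measured in an ADME assay on BHK-21 cells (Mesocricetus auratus) for cytotoxicity, read by MTT assay; on this read-out lower numbers stand for higher toxicity in this test and higher numbers for lower toxicity in this test:
compound 1, `CC(=O)c1ccc2c(c1)nc(-c1ccccc1)n2C1CCCCC1`: 100000 nM
compound 2, `CC(=O)c1ccc2c(c1)nc(-c1ccc(Cl)cc1)n2C1CCCCC1`: > 100000 nM, a limit of the assay and not a number
compound 3, `C/C(=N\NC(N)=S)c1ccc2c(c1)nc(-c1ccccc1)n2C1CCCCC1`: 38000 nM

Compound 1 and compound 2 differ by chloro in place of hydrogen on an aromatic carbon. The step of a number no lower from compound 1 to compound 2 (the limit leaves the size open) cannot be sized, because compound 2 sits at the limit of > 100000 nM in this assay, at which 1 of the 3 values shown sits.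

Compound 3 carries a different group on the shared core: a group of 7 heavy atoms (3 carbon, 3 nitrogen, 1 sulfur; no ring) in place of a group of 3 heavy atoms (2 carbon, 1 oxygen; no ring), on an aromatic carbon. That exchange gave a 2.6-fold lower number from compound 1 to compound 3 (0.42 log units; beyond the scatter), and compound 3 therefore holds the lowest number among the two read as numbers.

Compound 4 `C/C(=N\NC(N)=S)c1ccc2c(c1)nc(-c1ccc(Cl)cc1)n2C1CCCCC1` is not yet measured in this assay. It differs from compound 3 by chloro in place of hydrogen on an aromatic carbon, the same change that separates compound 1 from compound 2, on the same place of the phenyl ring; the two cores differ as told above for compound 1 and compound 3.

From compound 3 the step to compound 4 is expected to be about a 1.3-fold higher number from compound 3 to compound 4 (0.12 log units; within the scatter), resting on compound 1 going to compound 2 with a number no lower from compound 1 to compound 2 (the limit leaves the size open), which at least did not fall. The number for compound 4 is expected near 50000 nM, between 20000 nM and 120000 nM.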

Compound 4, half-maximal cytotoxic concentration: > 100000 nM
Compound 4 gave a limit, no number; the forecaster's own chance of this, stated with the estimate: 25%; middle value at least 2.0-fold (0.30 log units) from the limit.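

In this assay, phenyl to 4-chlorophenyl on the core of compound 3 gave an at least 2.6-fold higher number from compound 3 to compound 4 (0.42 log units; beyond the scatter), a step read against a limit of the assay for compound 4 and not against a number. Carried between the two cores, the change lowered the number on neither, but that is all the pair supports, and no agreement in size can be claimed: the same change on two cores in this assay, a number no lower (the limit leaves the size open) from compound 1 to compound 2 and an at least 2.6-fold higher number (0.42 log units; beyond the scatter) from compound 3 to compound 4; the limit leaves it open whether they differ The step between compound 2 and compound 4 cannot be read, and how far either compound lies past the top of the measurable range stays unknown: the limit of > 100000 nM in this assay, at which 2 of the 4 values shown sit.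

Whether chloro is particular in this respect stays open, as the compounds shown do not tell how fluoro, methoxy or an amine in the same place of the phenyl ring would read on either core. Also open, on these data alone, is whether the chloro step would hold if a longer chain replaced the cyclohexyl group or a carboxylic acid replaced the acetyl group.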